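Amide aryl substituent: dimethoxypyrimidinyl replaced by acetylphenyl

The source may report more compounds than this note shows. Statements on the series, on what has been measured and on what is new or still open speak of the compounds shown alone.

Compound 3 `CCOC(=O)CCCCCOc1cccc(CN(C(=O)c2ccc(-c3cnc(OC)nc3OC)cc2)C(C)C)c1` carries a 2,4-dimethoxypyrimidin-5-yl group on an aromatic carbon of the shared core. In an ADME assay on HEK293 cells (Homo sapiens) for cytotoxicity, read by CellTiter-Glo and resazurin assay, with a stated time of 72 h (a lower number here means that less compound is needed, a higher number that more compound is needed for the effect), compound 3 gives > 26000 nM, which is a limit of the assay and not a number. Compound 1 `CCOC(=O)CCCCCOc1cccc(CN(C(=O)c2ccccc2)C(C)C)c1` has hydrogen on that aromatic carbon; in this assay compound 1 gives > 26000 nM, again a limit. Compound 2 `CCOC(=O)CCCCCOc1cccc(CN(C(=O)c2ccc(-c3cccc(NC(C)=O)c3)cc2)C(C)C)c1` carries 3-acetamidophenyl there; in this assay compound 2 gives > 26000 nM, also a limit. Hence the step that the two limits leave unreadable from compound 1 to compound 3, the step that the two limits leave unreadable from compound 1 to compound 2 and the step that the two limits leave unreadable from compound 2 to compound 3 cannot be sized, because of the limit of > 26000 nM in this assay, at which 3 of the 3 values shown sit.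

Compound 4 `CCOC(=O)CCCCCOc1cccc(CN(C(=O)c2ccc(-c3cccc(C(C)=O)c3)cc2)C(C)C)c1` is the next member. The change is 3-acetylphenyl in place of 2,4-dimethoxypyrimidin-5-yl on an aromatic carbon. Every measured step at this aromatic carbon lies between limits, so none gives a direction or a size for the change. The only observation so far is that hydrogen, 3-acetamidophenyl and 2,4-dimethoxypyrimidin-5-yl have all left the value at the limit. The step that the limit leaves unreadable from compound 3 to compound 4 is therefore expected to be nominal only. Compound 4 is expected to give 40000 nM in this assay, between 26000 nM and 100000 nM, and most probably again only a limit rather than a number.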

Compound 4, half-maximal effective concentration: > 26000 nM
Compound 4 ended at the assay's limit (the forecaster's own chance of this, stated with the estimate: 85%); the middle value does not contradict the limit.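

The steps linking compound 4 with compound 1, compound 2 and compound 3 cannot be read, because each has a limit of the assay, not a number, at both ends: (the limit of > 26000 nM in this assay, at which 4 of the 4 values shown sit). As far as these compounds go, whether any group on this aromatic carbon moves the value in this assay off the limit, and in which direction, stays open.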